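Exchanging Chloro for Methylsulfanyl on Compound 2

The source may report more compounds than this note shows. Statements on the series, on what has been measured and on what is new or still open speak of the compounds shown alone.

Compound 1 `Cn1nnc(C(=O)CCCCCCc2ccccc2)n1` and compound 2 `O=C(CCCCCCc1ccccc1)c1ncc(Cl)o1` share the same core and differ only in the aromatic ring attached to the carbonyl carbon. In an assay on HEK-293T cells for inhibition of diacylglycerol lipase-alpha (Homo sapiens), read by colorimetric assay (on this read-out lower numbers stand for stronger inhibition and higher numbers for weaker inhibition), compound 1 reaches only the limit of the assay, > 10000 nM. Compound 2 likewise gives only a limit in this assay, > 10000 nM. For the measured compounds named here, the one measured step, a step that the two limits leave unreadable from compound 1 to compound 2, therefore cannot be read, since both of its ends sit at the limit of > 10000 nM in this assay, at which 2 of the 2 values shown sit.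

Compound 3 `CSc1cnc(C(=O)CCCCCCc2ccccc2)o1` differs from compound 2 by methylsulfanyl in place of chloro on an aromatic carbon. Going by the values given here, no measured step concerns this position, and the step from compound 1 to compound 2 offers no readable size, so the data give no direction for this change. Compound 3 is expected to remain at or near the limit of this assay, with an estimate of 10000 nM ranging from 2500 nM to 40000 nM. The expected step from compound 2 to compound 3 is a number no higher from compound 2 to compound 3 (the limit leaves the size open).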

Compound 3, half-maximal inhibitory concentration: > 10000 nM
Compound 3 gave a limit, no number; the forecaster's own chance of this, stated with the estimate: 70%; the middle value sits exactly at the limit.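

Compound 3 also gives only a limit in this assay, > 10000 nM. The steps to compound 3 from compound 2 and from compound 1 therefore cannot be read: the limit of > 10000 nM in this assay, at which 3 of the 3 values shown sit.

The compounds shown leave open whether exchanging chloro for methylsulfanyl changes inhibition at all, and by how much.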